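This account rests on a few compounds, and the source may have more. Where it says the series, first, only, none or still open, it means among the compounds named here.

Measured compounds in this series:

Compound 1, `CC(C)C(NC(=O)NO)C(=O)NC1CCCCC1` — in a functional assay on MOLT-4 cells (Homo sapiens) for inhibition (a lower number here means a stronger inhibitor, a higher number a weaker inhibitor), compound 1 gives > 100000 nM, which is a limit of the assay and not a number.
Compound 2, `CCC(C)C(NC(=O)NO)C(=O)NC1CCCCC1` — in this assay compound 2 gives 150000 nM.
Compound 3, `CC(C)C(NC(=O)n1nnc2ccccc21)C(=O)NC1CCCC1` — in this assay compound 3 gives > 200000 nM, again a limit and not a number.

The change from compound 1 to compound 2 is methyl in place of hydrogen on a saturated chain carbon, three bonds along the chain from an amide-type nitrogen and a carbonyl carbon. The step that the limit leaves unreadable from compound 1 to compound 2 cannot be read, because compound 1 sits at the limit of > 100000 nM in this assay, at which 1 of the 3 values shown sits.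

Compound 3 carries a different core; the difference between the core of compound 1 and the core of compound 3 is not broken down here. Compound 3 sits at the limit of > 200000 nM in this assay, at which 1 of the 3 values shown sits.

Compound 4, `CCC(C)C(NC(=O)n1nnc2ccccc21)C(=O)NC1CCCC1`, is not yet measured. It differs from compound 3 by methyl in place of hydrogen on a saturated chain carbon, three bonds along the chain from an amide-type nitrogen and a carbonyl carbon, the same kind of change as that from compound 1 to compound 2, at the same place. Within the data shown here, since the earlier step is unreadable and compound 3 itself reports only a limit, no direction for the step is available. The estimated step that the limit leaves unreadable from compound 3 to compound 4 rests on compound 3 staying near > 200000 nM. Compound 4 is expected to give about 250000 nM, within 100000 nM to 1000000 nM, most likely reported again as a limit.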

Compound 4, half-maximal inhibitory concentration: 94000 nM
For compound 4 the middle estimate is 2.7-fold (0.42 log units) above the measured one, outside the stated range (below it).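

In this assay, among these compounds, methyl in place of hydrogen on the core of compound 3 gives an at least 2.1-fold lower number from compound 3 to compound 4 (0.32 log units; beyond the scatter), which is beyond the scatter and is the only readable instance of this change. That step fixes a minimum size and not a true size, because compound 3 stands at a limit: the limit of > 200000 nM in this assay, at which 1 of the 4 values shown sits.

The same change on the core of compound 1 cannot be read, so nothing shows whether the change carries over between the two cores in direction or in size, because compound 1 also stands at a limit: the limit of > 100000 nM in this assay, at which 1 of the 4 values shown sits.

Open, going by these compounds, is whether a longer chain or a phenyl group at this place, in place of the sec-butyl, would move the number further on either core. Also open, on these data alone, is whether the lower number seen on the core of compound 3 would recur on a third core, as a single readable pair cannot establish a trend.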